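The source may hold more compounds than are shown below. What is called first, only, known or untested is meant among the compounds shown, and "the series" means these compounds.

Compound 1 `CC(C)(C)CC(=O)N1CCC(CCCC(=O)c2ncco2)CC1`: 90 nM
Compound 2 `O=C(CCCC1CCN(Cc2ccccc2)CC1)c1ncco1`: 315 nM
Compound 3 `Cc1ccc(CN2CCC(CCCC(=O)c3ncco3)CC2)cc1`: 400 nM

In an assay on isolated protein for inhibition of Fatty-acid amide hydrolase 1 (Homo sapiens) (on this read-out lower numbers stand for stronger inhibition and higher numbers for weaker inhibition), compound 1 gives the lowest number of the three. Its nearest neighbour is compound 2, with a 3.5-fold higher number from compound 1 to compound 2 (0.54 log units; beyond the scatter); the furthest is compound 3, with a 4.4-fold higher number from compound 1 to compound 3 (0.65 log units; beyond the scatter). Compound 4 `O=C(CCCC1CCN(Cc2ccc(Br)cc2)CC1)c1ncco1` differs from compound 1 in one place: 4-bromobenzyl in place of neopentylcarbonyl on an amine nitrogen in a ring. Two measured steps, in which a benzyl-type group likewise takes the place of neopentylcarbonyl on the amine nitrogen in the ring, bear directly on this change: a 3.5-fold higher number from compound 1 to compound 2 (0.54 log units; beyond the scatter) and a 4.4-fold higher number from compound 1 to compound 3 (0.65 log units; beyond the scatter). Between the two benzyl compounds, a 1.3-fold higher number from compound 2 to compound 3 (0.10 log units; within the scatter), so the methyl in place of hydrogen on an aromatic carbon has not moved the number beyond the scatter. The 4-bromobenzyl of compound 4 is therefore expected to behave like the benzyl and the 4-methylbenzyl, with a modest rise beyond the scatter, a 4.0-fold higher number from compound 1 to compound 4 (0.60 log units; beyond the scatter). Compound 4 is estimated at 360 nM, with a range from 150 nM to 850 nM.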

Compound 4, half-maximal inhibitory concentration: 45 nM
Beside the measured number, compound 4's estimate is 8.0-fold (0.90 log units) above it, outside the stated range (below it).
By their numbers in this assay, from the lowest: compounds 4 and 1 (each within the scatter of the next); then compounds 2 and 3 (each within the scatter of the next).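

In this assay adding bromo to the benzyl group gives a 7.0-fold lower number from compound 2 to compound 4 (0.85 log units; beyond the scatter) and bromo in place of methyl gives an 8.9-fold lower number from compound 3 to compound 4 (0.95 log units; beyond the scatter) whereas methyl in place of hydrogen gives only a 1.3-fold higher number from compound 2 to compound 3 (0.10 log units; within the scatter) so this carbon of the benzyl group responds to bromo in a way the methyl did not reveal. The step with 4-bromobenzyl in place of neopentylcarbonyl gives a 2.0-fold lower number from compound 1 to compound 4 (0.30 log units; within the scatter) and so, unlike the benzyl and the 4-methylbenzyl, this group stays within the scatter of compound 1 even though it has no carbonyl. Nothing at hand accounts for the gap between bromo and methyl. Going by these compounds, what chloro, methoxy or trifluoromethyl would do in place of the bromo remains open. So does whether bromo would give the same result on another carbon of the aromatic ring.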